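A few compounds are considered here, and "the series" means these few. Any claim that something is new, unique, unknown or untested is made for them only; others in the source may bear on it.

Of the compounds shown here, three of one series have been measured in an assay on CHO cells for displacement of a labelled ligand from transmembrane domain-containing protein TMIGD3 (Homo sapiens); a lower number here means a stronger inhibitor, a higher number a weaker inhibitor. Compound 1 `CCCn1c(-c2ccco2)nc2c(N)ncnc21` gives 790 nM. Compound 2 `CCCn1cnc2c(N)nc(NCc3ccccc3)nc21` gives 5840 nM. Compound 3 `CCCn1cnc2c(NCc3ccccc3)ncnc21` gives 29100 nM, the highest of the three numbers; compound 2 lies nearest to it, and compound 1 lies furthest from it, both gaps beyond the scatter. Compound 4 `CCCn1c(Br)nc2c(NCc3ccccc3)ncnc21` has not yet been measured. Compound 4 differs from compound 3 in one place only: bromo in place of hydrogen on an aromatic carbon. For the measured compounds named here, no pair among the measured compounds differs in this place alone, so nothing among the measured numbers shows how large such a step is. The expected step in this assay is a 2.4-fold lower number from compound 3 to compound 4 (0.38 log units; beyond the scatter), a modest move toward a lower number, with a move of either sign inside the scatter also regarded as plausible. Compound 4 is therefore expected to give about 12000 nM in this assay, within a range of 3000 nM to 50000 nM.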

Compound 4, inhibition constant: 11100 nM
For compound 4 the middle estimate is 1.1-fold (0.03 log units) above the measured one, and the stated range covers the measured number.
By their numbers in this assay, from the lowest: compound 1; then compounds 2 and 4 (each within the scatter of the next); then compound 3.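

In this assay, for the compounds shown here, the aromatic carbon between two ring nitrogen atoms, next to the ring atom that bears a propyl group, accepts bromo in place of hydrogen with a modest gain: the step of a 2.6-fold lower number from compound 3 to compound 4 (0.42 log units; beyond the scatter) is the first one-place change that can be read. Going by these compounds alone, compound 1 also carries a group at this carbon, but it differs from compound 3 in more than one place, so only this pair isolates a change here. No available measurement bears on why the step has this size and direction.

From the compounds shown here alone, it remains open whether an amine, a methyl group or a longer chain at this carbon would give a larger step or one of opposite sign. Going by these compounds, whether bromo gives a similar step on compound 2 also remains open.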